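Moving a Phenol from Meta to Para in Cytotoxicity

The source may report more compounds than this note shows. Statements on the series, on what has been measured and on what is new or still open speak of the compounds shown alone.

The study measures cytotoxicity in an ADME assay on MCF-10A cells (Homo sapiens) for cytotoxicity, read by CCK-8 assay and cell counting, with a stated time of 72 h; a higher number here means a weaker inhibitor, a lower number a stronger inhibitor. Of the compounds shown here, two have been measured so far. Compound 1 `COc1cc(OC)cc(-c2cc3ccccc3c(-c3cccc(N)c3)n2)c1` gives only a limit in this assay: for compound 1 the result is > 50000 nM, which is a limit and not a number. Compound 2 `COc1ccc(-c2cc3cc(C)ccc3c(-c3cccc(O)c3)n2)cc1OC` gives 13500 nM. Compound 2 thus holds the only actual number shown, the other value being a limit (the limit of > 50000 nM in this assay, at which 1 of the 2 values shown sits).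

The unmeasured compound 3 `COc1ccc(-c2cc3cc(C)ccc3c(-c3ccc(O)cc3)n2)cc1OC` differs from compound 2 by 4-hydroxyphenyl in place of 3-hydroxyphenyl on an aromatic carbon. Among the measured compounds shown here, no pair of measured compounds differing in one place is available here, so no measured step guides the expectation. Moving the hydroxyl around a phenyl ring, with the same atoms joined differently, is expected to produce a step in this assay no larger than the scatter of repeated measurements, in either direction. Compound 3 is therefore estimated at 15000 nM, within a range of 5000 nM to 50000 nM. The expected step from compound 2 to compound 3 is a 1.1-fold higher number from compound 2 to compound 3 (0.05 log units; within the scatter).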

Compound 3, half-maximal inhibitory concentration: 18100 nM
For compound 3 the middle estimate is 1.2-fold (0.08 log units) below the measured one, within the range that was stated.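

In this assay, among the compounds shown here, the exchange of 3-hydroxyphenyl for 4-hydroxyphenyl on the aromatic carbon next to the ring nitrogen gives the first measured comparison of two compounds that differ in one place: a 1.3-fold higher number from compound 2 to compound 3 (0.13 log units; within the scatter). This step lies within the scatter, so the assay does not separate compound 2 from compound 3, and at this position neither hydroxyl placement can be called the stronger or the weaker inhibitor. Compound 1 gives only a limit, not a number, and it differs from compound 2 and compound 3 in more than one place, so it cannot be set against either of them: the limit of > 50000 nM in this assay, at which 1 of the 3 values shown sits.

The compounds shown leave open whether a group other than a hydroxyl on this phenyl ring, such as a carboxylic acid, would give a step beyond the scatter, and whether 2-hydroxyphenyl would read the same as 3-hydroxyphenyl and 4-hydroxyphenyl. They also leave open whether the same exchange would give a step of similar size on a core without the methyl group or with other methoxy groups.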